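A few compounds are considered here, and "the series" means these few. Any claim that something is new, unique, unknown or untested is made for them only; others in the source may bear on it.

Measured compounds: compound 1 `COc1cc(Nc2ncnc3c(NC(=O)Nc4ccccc4Cl)cccc23)cc(OC)c1`, 356 nM; compound 2 `COc1cc(Nc2ncnc3c(NC(=O)Nc4ccc(Cl)cc4Cl)cccc23)cc(OC)c1`, 3060 nM; compound 3 `COc1cc(Nc2ncnc3c(NC(=O)Nc4ccc(C(F)(F)F)cc4)cccc23)cc(OC)c1`, 3920 nM.

In a functional assay on RT-112 cells (Homo sapiens) for antiproliferative activity, read by MTT assay, with a stated time of 72 h (a lower number here means a stronger inhibitor of growth, a higher number a weaker inhibitor of growth), compound 1 gives 356 nM. The change chloro in place of hydrogen on an aromatic carbon produced an 8.6-fold higher number from compound 1 to compound 2 (0.93 log units; beyond the scatter). The cores of compound 1 and compound 3 differ by 4-(trifluoromethyl)phenyl in place of 2-chlorophenyl on an amide-type nitrogen, a change that gave an 11-fold higher number from compound 1 to compound 3 (1.04 log units; beyond the scatter), while a 1.3-fold higher number from compound 2 to compound 3 (0.11 log units; within the scatter).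

Compound 4 `COc1cc(Nc2ncnc3c(NC(=O)Nc4ccc(C(F)(F)F)cc4Cl)cccc23)cc(OC)c1` differs from compound 3 by chloro in place of hydrogen on an aromatic carbon. This is the same kind of change as from compound 1 to compound 2, not the same: there the entering chloro sat meta to a chloro group and para to a large group, here it sits ortho to a large group and meta to a trifluoromethyl group.

Compound 4 is therefore expected to show a smaller step than the earlier one, namely a 1.7-fold higher number from compound 3 to compound 4 (0.22 log units; within the scatter), resting on compound 1 to compound 2 having given an 8.6-fold higher number from compound 1 to compound 2 (0.93 log units; beyond the scatter). Compound 4 is estimated at 6500 nM, between 2000 nM and 20000 nM.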

Compound 4, concentration for 50% growth inhibition: 1080 nM
For compound 4 the middle estimate is 6.0-fold (0.78 log units) above the measured one; measured number outside the range, below it.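

In this assay, chloro in place of hydrogen on the aromatic carbon gave a 3.6-fold lower number from compound 3 to compound 4 (0.56 log units; beyond the scatter), and the same change on the two cores did not carry over, since the steps run in opposite directions: the same change on two cores in this assay, an 8.6-fold higher number (0.93 log units; beyond the scatter) from compound 1 to compound 2 and a 3.6-fold lower number (0.56 log units; beyond the scatter) from compound 3 to compound 4, 31-fold (1.49 log units) apart, beyond the scatter of two such steps

Trifluoromethyl gave a 2.8-fold lower number from compound 2 to compound 4 (0.45 log units; beyond the scatter) when it replaced chloro, and a 3.0-fold higher number from compound 1 to compound 4 (0.48 log units; beyond the scatter) when it replaced hydrogen. The outcome of adding this chloro therefore cannot be carried from one core to another in this series, though two pairs do not show why the steps differ or how the change would behave on a further core.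

The compounds shown leave open whether a methoxy group or an amine in place of the trifluoromethyl group would follow the step seen with compound 2 or that seen with compound 4.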